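A few compounds are considered here, and "the series" means these few. Any claim that something is new, unique, unknown or untested is made for them only; others in the source may bear on it.

Of the compounds shown here, three have so far been tested in an ADME assay on MT2 cells (Homo sapiens) for cytotoxicity, read by MTT assay; a higher number here means that more compound is tolerated, a lower number that less compound is tolerated. Compound 1 `N#Cc1cc2c(Oc3ccc(F)cc3OCCn3ccc(=O)[nH]c3=O)cccn2c1` gives 100000 nM. Compound 3 `N#Cc1cc2c(Oc3ccc(F)cc3OCCn3ccc(=O)[nH]c3=O)cc(Cl)cn2c1` differs from compound 1 by chloro in place of hydrogen on an aromatic carbon, and in this assay compound 3 gives 15000 nM, so that a 6.7-fold lower number from compound 1 to compound 3 (0.82 log units; beyond the scatter). Compound 2 `N#Cc1ccc2c(Oc3ccccc3OCCn3ccc(=O)[nH]c3=O)cc(Cl)cc2c1` has a different core; how its core differs from that of compound 1 is not broken down here. In this assay compound 2 gives 24000 nM.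

Compound 4 `N#Cc1ccc2c(Oc3ccc(Cl)cc3OCCn3ccc(=O)[nH]c3=O)cc(Cl)cc2c1` has not yet been tested. It differs from compound 2 by chloro in place of hydrogen on an aromatic carbon. This is the same kind of change as that from compound 1 to compound 3, but not the same: there the chloro entered a six-membered aromatic ring with 1 nitrogen, part of a fused or bridged system of two rings, two atoms from the ring nitrogen, meta to a fused ring and para to a fused ring, whereas here it enters a six-membered aromatic ring of carbon only, meta to a large group and para to a large group. Because a 6.7-fold lower number from compound 1 to compound 3 (0.82 log units; beyond the scatter) is only a modest drop, and the surroundings of the new chloro are not the same, the step expected here is a 2.4-fold lower number from compound 2 to compound 4 (0.38 log units; beyond the scatter). For compound 4 the expected value in this assay is 10000 nM, most likely between 4000 nM and 25000 nM.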

Compound 4, half-maximal cytotoxic concentration: 20000 nM
For compound 4 the middle estimate is 2.0-fold (0.30 log units) below the measured one; the measured number falls inside the stated range.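

In this assay, chloro in place of hydrogen on the six-membered aromatic ring of carbon only gives a 1.2-fold lower number from compound 2 to compound 4 (0.08 log units; within the scatter) and so leaves the two compounds indistinguishable in this read-out. The same kind of change therefore does not carry the same size of step from one core to the other: the same change on two cores in this assay, a 6.7-fold lower number (0.82 log units; beyond the scatter) from compound 1 to compound 3 and a 1.2-fold lower number (0.08 log units; within the scatter) from compound 2 to compound 4, 5.6-fold (0.74 log units) apart, beyond the scatter of two such steps. This rests on just two pairs, in which the chloro enters different rings and the compounds also differ elsewhere, so it does not show which difference accounts for the gap or how a third core would respond.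

The compounds shown leave open how other groups at the place taken by the chloro in compound 4, such as a methyl, a methoxy or an amine, would behave in this assay. They also leave open whether a carboxylic acid there would give a step closer to the small one or the larger one.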